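This account rests on a few compounds, and the source may have more. Where it says the series, first, only, none or still open, it means among the compounds named here.

Working notes on the series. Going by the values given here, compound 1 `O=C(CCCCCCCc1ccccc1)C(F)(F)F` is the only member with a single settled number in an assay on isolated protein for binding affinity to Fatty-acid amide hydrolase 1 (Mus musculus), read by radioligand binding and fluorescence (on this read-out lower numbers stand for stronger inhibition and higher numbers for weaker inhibition), where compound 1 gives 25 nM; the other two measured members each carry several entries that do not agree with one another. Compound 2 `O=C(CCCCCCCc1ccccc1)c1nnc(-c2ccccn2)o1` gives 3200 nM; 0.77 nM (2 entries) in this assay, as shown by the several entries of compound 2 in this assay, 3200 nM; 0.77 nM (2 entries), and compound 3 `O=C(CCCCCc1ccccc1)c1nnc(-c2ccccn2)o1` gives 560 nM; 0.85 nM (2 entries), as shown by the several entries of compound 3 in this assay, 560 nM; 0.85 nM (2 entries), so neither fixes a single point of comparison. Compound 4 `CCCCCCCCCC(=O)C(F)(F)F` differs from compound 1 by ethyl in place of phenyl on a saturated chain carbon, seven bonds along the chain from a carbonyl carbon. Among the compounds with values here, no measured pair covers this change, so the expectation rests on compound 1 alone. The step is expected to lie beyond the scatter, towards weaker inhibition, at a 12-fold higher number from compound 1 to compound 4 (1.08 log units; beyond the scatter). Compound 4 is therefore estimated at 300 nM in this assay, within 60 nM to 2000 nM.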

Compound 4, inhibition constant: 130 nM
Compound 4: the middle estimate sits 2.3-fold (0.36 log units) above what was measured, within the range that was stated.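

In this assay, going by these compounds alone, the first measured step at this position shows that the phenyl on a saturated chain carbon, seven bonds along the chain from a carbonyl carbon, is not interchangeable with ethyl: the change gives a 5.2-fold higher number from compound 1 to compound 4 (0.72 log units; beyond the scatter). The step is modest, and compound 4 keeps a measurable inhibition constant with no ring in the chain. No available evidence bears on the reason for this step. Open, from the compounds shown here alone, is whether cyclohexyl or a longer chain in place of phenyl would return the number of compound 1. Also open, going by these compounds, is whether the same change behaves alike on the core of compound 2, whose entries disagree.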